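This account rests on a few compounds, and the source may have more. Where it says the series, first, only, none or still open, it means among the compounds named here.

Measured compounds in a functional assay on A549 cells (Homo sapiens) for antiproliferative activity, read by MTT assay, with a stated time of 48 h; on this read-out lower numbers stand for stronger inhibition and higher numbers for weaker inhibition:
compound 1, `CCOc1ccccc1-n1nncc1CN1C(=O)C2(C(C#N)=C(N)Oc3c2c2nc4ccccc4nc2c2ccccc32)c2ccccc21`, reported only as a limit of the assay: > 50000 nM
compound 2, `N#CC1=C(N)Oc2c(c3nc4ccccc4nc3c3ccccc23)C12C(=O)N(Cc1cnnn1-c1ccc(S(N)(=O)=O)cc1)c1ccccc12`, reported only as a limit of the assay: > 50000 nM
compound 3, `CCOc1ccccc1-n1nncc1CN1C(=O)C2(C(C#N)=C(N)Oc3c(N)cc4nc5ccccc5nc4c32)c2ccccc21`, reported only as a limit of the assay: > 50000 nM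

Compound 3 stands where every other measured compound stands, at the upper limit of this assay; none of the three has a number, since (the limit of > 50000 nM in this assay, at which 3 of the 3 values shown sit). No ordering among compound 1, compound 2 and compound 3 can be read from these limits.

Among the measured compounds shown here, the only single-point step among the measured compounds, a step that the two limits leave unreadable from compound 1 to compound 2, is also an exchange of the aryl group on the aromatic nitrogen of the five-membered ring, but both of its ends are limits, so it gives no size and no direction.

Compound 4 is `N#CC1=C(N)Oc2c(N)cc3nc4ccccc4nc3c2C12C(=O)N(Cc1cnnn1-c1c(Cl)cc(Cl)cc1Cl)c1ccccc12`. It differs from compound 3 by 2,4,6-trichlorophenyl in place of 2-ethoxyphenyl on an aromatic nitrogen. That change is of the same kind as the step from compound 1 to compound 2, and that step is unreadable; so nothing measured sets a size or a direction for the step into compound 4 in this assay, and the three limits give no reason to expect a number at all.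

Compound 4 is therefore estimated at 60000 nM, in a range from 20000 nM to 200000 nM, most likely reported again as a limit. This estimate means an expected step that the limit leaves unreadable from compound 3 to compound 4, within the scatter.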

Compound 4, half-maximal inhibitory concentration: > 50000 nM
Compound 4 was reported as a limit; the forecaster's own chance of this, stated with the estimate: 80%; the middle value does not contradict the limit.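

In this assay compound 4 gives > 50000 nM, which is a limit of the assay and not a number. No size or direction can be read for the step from compound 3 to compound 4: the limit of > 50000 nM in this assay, at which 4 of the 4 values shown sit.

The compounds shown leave open whether any aryl group on that aromatic nitrogen would give a measurable value in this assay.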